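The source may report more compounds than this note shows. Statements on the series, on what has been measured and on what is new or still open speak of the compounds shown alone.

Measured so far in an ADME assay on HepG2 cells (Homo sapiens) for cytotoxicity, with a stated time of 48 h; a higher number here means a weaker inhibitor, a lower number a stronger inhibitor:

compound 1, `Cn1c(SCc2ccc(Br)cc2)nnc1-c1cc([N+](=O)[O-])cc([N+](=O)[O-])c1`: > 30000 nM, a limit of the assay and not a number.
compound 2, `Cn1c(SCc2ccc(Cl)cc2)nnc1-c1cc([N+](=O)[O-])cc([N+](=O)[O-])c1`: > 30000 nM, likewise a limit.
compound 3, `O=[N+]([O-])c1cc(-c2nnc(SCc3ccc(Br)cc3)n2Cc2ccccc2)cc([N+](=O)[O-])c1`: > 30000 nM, again a limit.

The change from compound 1 to compound 2 is chloro in place of bromo on an aromatic carbon. Its step, a step that the two limits leave unreadable from compound 1 to compound 2, cannot be sized because of the limit of > 30000 nM in this assay, at which 3 of the 3 values shown sit.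

Compound 3 carries a different core; the difference from compound 1 is phenyl in place of hydrogen on a saturated chain carbon bound to an aromatic nitrogen. The step that the two limits leave unreadable from compound 1 to compound 3 is equally unreadable because of the limit of > 30000 nM in this assay, at which 3 of the 3 values shown sit.

Compound 4, `O=[N+]([O-])c1cc(-c2nnc(SCc3ccc(Cl)cc3)n2Cc2ccccc2)cc([N+](=O)[O-])c1`, is not yet measured. From compound 3 it differs by chloro in place of bromo on an aromatic carbon, which is the same change already made from compound 1 to compound 2, the place being described in identical words in both cases.

For compound 4 in this assay the step expected from the change is a step that the limit leaves unreadable from compound 3 to compound 4, which rests on compound 3 sitting at a limit, > 30000 nM, and on the earlier step that the two limits leave unreadable from compound 1 to compound 2 having left both partners at that same limit. The estimate for compound 4 is therefore 50000 nM, within 15000 nM and 200000 nM, and most likely the assay will again report only a limit.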

Compound 4, half-maximal inhibitory concentration: > 30000 nM
Compound 4: only a limit was reported (the forecaster's own chance of this, stated with the estimate: 85%); the middle value lies beyond the limit too.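

In this assay compound 4 gives > 30000 nM as a limit of the assay and not a number. Neither step into compound 4, from compound 3 or from compound 2, can be read, because all values sit at one limit: the limit of > 30000 nM in this assay, at which 4 of the 4 values shown sit.

The compounds shown leave open how the four compare in cytotoxicity, and whether either change has any effect on it.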